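The source may report more compounds than this note shows. Statements on the series, on what has been measured and on what is new or still open speak of the compounds shown alone.

Compound 1 `COCC#Cc1cc(C(O)(C(F)(F)F)C(F)(F)F)cnc1N1CCN(S(=O)(=O)c2ccc(N)nc2)CC1`: 399 mL.min-1.g-1 in an ADME assay (liver) for metabolic stability, with Liver microsome (Rattus norvegicus) as the target, using microsomes and NADPH, with a stated time of 30 min, tested at 1 uM; a higher number here means faster removal of the compound, a lower number slower removal
Compound 2 `Nc1ccc(S(=O)(=O)N2CCN(c3ncc(C(O)(C(F)(F)F)C(F)(F)F)cc3-c3ccccc3O)CC2)cn1`: 125 mL.min-1.g-1

Compound 2 holds the lower of these two numbers, with a 3.2-fold lower number from compound 1 to compound 2 (0.50 log units; beyond the scatter) separating them. Compound 3 `Nc1ccc(S(=O)(=O)N2CCN(c3ncc(C(O)(C(F)(F)F)C(F)(F)F)cc3-c3cncc(F)c3)CC2)cn1` differs from compound 2 by 5-fluoropyridin-3-yl in place of 2-hydroxyphenyl on an aromatic carbon. Within the data shown here, the one measured step, a 3.2-fold lower number from compound 1 to compound 2 (0.50 log units; beyond the scatter), changed the group at this same aromatic carbon but started from a different group, so it gives no direction for this exchange. In this assay the expected step is therefore a 1.4-fold higher number from compound 2 to compound 3 (0.16 log units; within the scatter), not beyond the scatter. Compound 3 is estimated at 180 mL.min-1.g-1, with a range from 70 mL.min-1.g-1 to 450 mL.min-1.g-1.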

Compound 3, intrinsic clearance in microsomes: 19 mL.min-1.g-1
For compound 3 the middle estimate is 9.5-fold (0.98 log units) above the measured one, outside the stated range (below it).
By their numbers in this assay, from the lowest: compound 3; then compound 2; then compound 1.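

In this assay the group on this aromatic carbon can move the number much further than the first step showed: 5-fluoropyridin-3-yl in place of 2-hydroxyphenyl gives a 6.6-fold lower number from compound 2 to compound 3 (0.82 log units; beyond the scatter) and in place of 3-methoxyprop-1-yn-1-yl gives a 21-fold lower number from compound 1 to compound 3 (1.32 log units; beyond the scatter). Having an aromatic ring at this carbon therefore does not settle the number, since the two rings here give clearly different results. No measurement shown explains the difference. On these data alone, it remains open whether the ring nitrogen or the fluorine matters more, and how plain phenyl, pyridin-3-yl without fluorine, or an amine such as morpholine would behave at this carbon.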